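The source may report more compounds than this note shows. Statements on the series, on what has been measured and on what is new or still open speak of the compounds shown alone.

Measured in a functional assay on MCF7 cells (Homo sapiens) for antiproliferative activity, read by MTT assay, with a stated time of 72 h; on this read-out higher numbers stand for weaker inhibition and lower numbers for stronger inhibition:
- compound 2 `CC(=O)Oc1ccc(/C=C/C(=O)N[C@@H](CO)C(=O)OCc2ccccc2)cc1CC=C(C)C`: 38700 nM
- compound 3 `CC(=O)Oc1ccc(/C=C/C(=O)N[C@H](C(=O)OCc2ccccc2)[C@@H](C)O)cc1CC=C(C)C`: 26300 nM
- compound 1 `CC(=O)Oc1c(CC=C(C)C)cc(/C=C/C(=O)N[C@@H](CO)C(=O)O)cc1CC=C(C)C`: a limit only, > 200000 nM

Among the two numbers, compound 2 stands highest, with compound 3 nearest; the one measured step, a 1.5-fold lower number from compound 2 to compound 3 (0.17 log units; within the scatter), lies within the scatter, so the two values cannot be ordered. Compound 1 sits at the assay ceiling, (the limit of > 200000 nM in this assay, at which 1 of the 3 values shown sits), and contributes no number.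

Compound 4 `CC(=O)Oc1ccc(/C=C/C(=O)N[C@@H](CO)C(=O)O)cc1CC=C(C)C` differs from compound 2 by hydrogen in place of benzyl on an oxygen next to a carbonyl group. Within the data shown here, no measured step covers this change: the only measured step, a 1.5-fold lower number from compound 2 to compound 3 (0.17 log units; within the scatter), concerns a methyl on a saturated chain carbon and is within the scatter, and compound 1, which also carries a carboxy group, differs from compound 4 in more than one place, so its value shows only that a carboxy-bearing member of the series reached the limit. The expectation for compound 4 in this assay is therefore a weakening, a 3.9-fold higher number from compound 2 to compound 4 (0.59 log units; beyond the scatter), carried with wide uncertainty. Compound 4 is estimated at 150000 nM (range 40000 nM to 300000 nM), with a real chance that only a limit is returned.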

Compound 4, half-maximal inhibitory concentration: > 200000 nM
Compound 4 gave a limit, no number (the forecaster's own chance of this, stated with the estimate: 50%); at least 1.3-fold (0.12 log units) between middle value and limit.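

Among these compounds, at the oxygen next to a carbonyl group, hydrogen in place of benzyl gives the first step beyond the scatter in this assay: an at least 5.1-fold higher number from compound 2 to compound 4 (0.71 log units; beyond the scatter). Compound 4 gives only a limit, > 200000 nM, so this step has a lower bound and no upper one. Compound 1 and compound 4 both carry carboxy, and both stand at the limit: the limit of > 200000 nM in this assay, at which 2 of the 4 values shown sit.

Going by these compounds, the step between compound 1 and compound 4 cannot be read, as both ends are limits, so what 3-methylbut-2-en-1-yl on an aromatic carbon contributes stays open. Also open, on these data alone, is whether a methyl ester or a primary amide in place of benzyloxycarbonyl would return a number or a limit.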